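Arylidene hydrazone variation on a shared triazolopyrimidine-type core

A few compounds are considered here, and "the series" means these few. Any claim that something is new, unique, unknown or untested is made for them only; others in the source may bear on it.

Measured compounds:
- compound 1 `CCCSc1nc(N/N=C/c2ccccc2Cl)c2nnn(Cc3ccccc3)c2n1`: 13800 nM
- compound 2 `C/C(=N\Nc1nc(SCc2ccccc2)nc2c1nnn2Cc1ccccc1)c1ccccc1O`: 950 nM
- compound 3 `CCCSc1nc(N/N=C/c2ccc([N+](=O)[O-])cc2)c2nnn(Cc3ccccc3)c2n1`: 11000 nM

In a functional assay on MCF7 cells (Homo sapiens) for antiproliferative activity, read by MTT assay, with a stated time of 72 h (on this read-out lower numbers stand for stronger inhibition and higher numbers for weaker inhibition), compound 1 gives the highest of the three numbers. Compound 3 sits nearest, with a 1.3-fold lower number from compound 1 to compound 3 (0.10 log units; within the scatter). Among the measured compounds shown here, compound 2 lies furthest off, but it differs from compound 1 in more than one place, so its two values alone show only that the gap is beyond the scatter; no single step is counted for that pair.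

Compound 4 `CCCSc1nc(N/N=C(\C)c2ccc(Br)cc2)c2nnn(Cc3ccccc3)c2n1` is not yet measured. Relative to compound 1 the change is a group of 10 heavy atoms (8 carbon, 1 nitrogen, 1 bromine; one six-membered aromatic ring of carbon only) in place of a group of 9 heavy atoms (7 carbon, 1 nitrogen, 1 chlorine; one six-membered aromatic ring of carbon only), on a nitrogen on an aromatic ring. For the measured compounds named here, the one measured step that bears on this is the aryl swap from compound 1 to compound 3, which was within the scatter. The step to compound 4 also adds a methyl on the carbon with a double bond to nitrogen, for which no single-step comparison exists here. The expectation is therefore a small step, if any, with a 1.5-fold lower number from compound 1 to compound 4 (0.19 log units; within the scatter), leaning slightly toward a lower number. Compound 4 is estimated at 9000 nM, within a range of 3000 nM to 27000 nM.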

Compound 4, half-maximal inhibitory concentration: 13000 nM
The estimate for compound 4 lay 1.4-fold (0.16 log units) below the measured number; low and high end bracket the measured number.
By their numbers in this assay, from the lowest: compound 2; then compounds 3, 4 and 1 (each within the scatter of the next).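

In this assay, the group of 10 heavy atoms (8 carbon, 1 nitrogen, 1 bromine) in place of the group of 9 heavy atoms (7 carbon, 1 nitrogen, 1 chlorine), on a nitrogen on an aromatic ring, gives a 1.1-fold lower number from compound 1 to compound 4 (0.03 log units; within the scatter) as its step. This adds a second step at this position that stays within the scatter, and unlike the earlier aryl swap it includes a methyl on the carbon with a double bond to nitrogen. No measured evidence on the cause of this result is at hand.

As far as these compounds go, compound 2 at 950 nM differs from compound 1 in more than one place, so which difference goes with its value stays open. From the compounds shown here alone, whether an amine or a carboxylic acid on the aromatic ring of this group would give a step beyond the scatter also stays open.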